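Methyl on the hydroxy oxygen of compound 1

The source may report more compounds than this note shows. Statements on the series, on what has been measured and on what is new or still open speak of the compounds shown alone.

For the measured compounds named here, in a functional assay on NCI-H23 cells (Homo sapiens) for antiproliferative activity, read by sulforhodamine B assay, with a stated time of 48 h (on this read-out lower numbers stand for stronger inhibition and higher numbers for weaker inhibition), compound 1 (`O=C(NCCCNc1cc(-c2cn(-c3ccccc3)nc2-c2cccc(O)c2)ccn1)Nc1ccc(F)cc1`) gives 3110 nM and has only one measured neighbour. That neighbour is compound 2 (`O=C(NCCCNc1cc(-c2cn(-c3ccccc3)nc2-c2cccc(O)c2)ccn1)Nc1cccc(C(F)(F)F)c1`) at 4340 nM, and the two values lie within the scatter of each other, so compound 1 stands apart from nothing yet. Compound 3 (`COc1cccc(-c2nn(-c3ccccc3)cc2-c2ccnc(NCCCNC(=O)Nc3ccc(F)cc3)c2)c1`) differs from compound 1 by methyl in place of hydrogen on an oxygen on an aromatic ring, that is, 3-hydroxyphenyl to 3-methoxyphenyl. Going by the values given here, the only measured step (a 1.4-fold higher number from compound 1 to compound 2 (0.14 log units; within the scatter)) lies elsewhere, on an amide-type nitrogen, and no measured pair tests the hydroxy group. That step therefore gives only a rough scale for a small change in this series, not a direct guide. A modest move towards a higher number is expected, with the direction uncertain and the size close to the scatter. The estimated step is a 1.4-fold higher number from compound 1 to compound 3 (0.16 log units; within the scatter) in this assay as a working expectation. For compound 3 the expected value is 4500 nM, within an estimated range of 1800 nM to 11000 nM in this assay.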

Compound 3, half-maximal inhibitory concentration: 10100 nM
Beside the measured number, compound 3's estimate is 2.2-fold (0.35 log units) below it; the measured number falls inside the stated range.
By their numbers in this assay, from the lowest: compounds 1 and 2 (each within the scatter of the next); then compound 3.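

In this assay, for the compounds shown here, the hydroxy oxygen is the first place where a single change moves the number beyond the scatter, with a 3.2-fold higher number from compound 1 to compound 3 (0.51 log units; beyond the scatter). Going by these compounds alone, the step on the amide-type nitrogen stays within the scatter by comparison, at a 1.4-fold higher number from compound 1 to compound 2 (0.14 log units; within the scatter), so the series so far responds more clearly at this oxygen than at that nitrogen, though each place rests on a single pair. The change from 3-hydroxyphenyl to 3-methoxyphenyl adds only one carbon, yet it gives modestly weaker inhibition on this read-out, so the hydrogen on this oxygen cannot be replaced by methyl without a measurable cost on the background of compound 1; no measured information is at hand that accounts for this step.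

On these data alone, it remains open whether the same change has a similar size on the background of compound 2, where the 3-(trifluoromethyl)phenyl group is present. As far as these compounds go, it is also open whether the cost belongs to methyl alone or extends to other groups at this place, such as an ethoxy group, an amine or a carboxylic acid.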